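This account rests on a few compounds, and the source may have more. Where it says the series, first, only, none or still open, it means among the compounds named here.

Working notes on the series, read in a functional assay on PC-3 cells (Homo sapiens) for inhibition, read by MTT assay, with a stated time of 72 h; on this read-out higher numbers stand for weaker inhibition and lower numbers for stronger inhibition. For the measured compounds named here, compound 1 `FC(F)(F)c1ccc(CSc2nc(N3CCN(c4ccccc4)CC3)cc(C(F)(F)F)n2)cc1` gives 42700 nM, the only actual number so far. Compound 2 `FC(F)(F)c1ccc(CSc2nc(Sc3ncccn3)cc(C(F)(F)F)n2)cc1` gives > 50000 nM, which is a limit of the assay and not a number. Going by the values given here, no measured pair isolates a single change, so the next step has no direct precedent. Compound 3 `Cc1nnc(Sc2cc(C(F)(F)F)nc(SCc3ccc(C(F)(F)F)cc3)n2)s1` differs from compound 2 by 5-methyl-1,3,4-thiadiazol-2-yl in place of pyrimidin-2-yl on a sulfur, with 5-methyl-1,3,4-thiadiazol-2-yl in place of pyrimidin-2-yl on a sulfur. Among the compounds with values here, the one number available, compound 1 at 42700 nM, offers no sign of strong inhibition, so compound 3 is expected to remain weak. The expected at least 1.1-fold lower number from compound 2 to compound 3 (0.04 log units; that floor lies within the scatter) is no larger than the scatter, with no firm direction. For compound 3 the estimate is 45000 nM, with an expected range of 15000 nM to 90000 nM.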

Compound 3, half-maximal inhibitory concentration: > 50000 nM
Compound 3: a limit, no number (the forecaster's own chance of this, stated with the estimate: 55%); middle value at least 1.1-fold (0.04 log units) away from the limit.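

In this assay compound 2 and compound 3 both sit at a limit of the assay and not at a number, so the step between them cannot be read: the limit of > 50000 nM in this assay, at which 2 of the 3 values shown sit.

Going by these compounds, whether 5-methyl-1,3,4-thiadiazol-2-yl and pyrimidin-2-yl on a sulfur differ at all in inhibition stays open.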